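Moving the chlorine from one ring carbon to another

The source may hold more compounds than are shown below. What is called first, only, known or untested is meant among the compounds shown, and "the series" means these compounds.

Measured so far:
compound 1, `O=C1CSC(c2cccc(Cl)c2)N1CCN1CCCCC1` — 31%
compound 2, `O=C1CSC(c2cccc(F)c2)N1CCN1CCCCC1` — 27%

Both compounds share the same core and differ only in the halogen on the aromatic ring. In an ADME assay on Vero cells (Chlorocebus sabaeus) for cytotoxicity, read by neutral red uptake, tested at 787 ug/mL (a higher number here means a weaker effect of the compound at the concentration tested, a lower number a stronger effect), compound 1 gives 31%, and compound 2 gives 27%. Among the compounds with values here, the one measured step, a number 4 percentage points lower from compound 1 to compound 2 (within the scatter), shows that swapping the halogen left the read-out essentially unchanged. Compound 2 thus stands at one end of two numbers that are within the scatter of each other, so nothing can be said about its rank.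

Compound 3, `O=C1CSC(c2ccccc2Cl)N1CCN1CCCCC1`, has not been measured. The change is 2-chlorophenyl in place of 3-fluorophenyl on a saturated ring carbon. Within the data shown here, no measured step addresses a chlorine on a different ring carbon; the only comparison at hand is the halogen swap, which was within the scatter. With so little to go on, the expected step of a number 3 percentage points higher from compound 2 to compound 3 (within the scatter) is no larger than the scatter, in no particular direction. Compound 3 is therefore expected to give 30%, with a likely range from 15% to 45%.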

Compound 3, a percentage reported as activity, at one concentration (the size of the read-out at that concentration, not a potency): 38%
For compound 3 the middle estimate is 8 percentage points below the measured one; the measured number falls inside the stated range.
By their numbers in this assay, from the lowest: compounds 2, 1 and 3 (each within the scatter of the next, the first and the last beyond it).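

In this assay, within the data shown here, the change to 2-chlorophenyl in place of 3-fluorophenyl on the saturated ring carbon gives a number 11 percentage points higher from compound 2 to compound 3 (beyond the scatter) and is the first step at this position to clear the usual scatter, though only modestly, and it points to a weaker effect at the concentration tested. The chlorine-only comparison, 2-chlorophenyl in place of 3-chlorophenyl, gives a number 7 percentage points higher from compound 1 to compound 3 (within the scatter) and so does not separate the two chlorine placements, which means the step beyond the scatter cannot be pinned on the chlorine's ring carbon alone, while the step from fluorine to chlorine also changes both the halogen and its place at once. No available information bears on why these read-outs differ.

The compounds shown leave open how fluorine would behave on the same ring carbon as the chlorine in 2-chlorophenyl, and so whether the halogen or its place matters more. They also leave open what a plain phenyl ring with no halogen, or a phenyl ring carrying a methoxy group or an amine, would give at this position.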